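A 7-chloroquinolin-4-yl swap on compound 1

This account rests on a few compounds, and the source may have more. Where it says the series, first, only, none or still open, it means among the compounds named here.

In a physicochemical assay (a higher number here means that more compound is needed for the effect, a lower number that less compound is needed), compound 1 `COc1cc(/C=N/NC(=O)c2nn(-c3ccc(Cl)cc3Cl)c(-c3ccc(Cl)cc3)c2C)ccc1O` gives 3550000 nM and compound 2 `COc1cc(/C=N/NC(=O)c2nn(-c3ccc(Cl)c(Cl)c3)c(-c3ccc(Cl)cc3)c2C)ccc1O` gives 2600000 nM, two values within the scatter of each other. Compound 3 `COc1cc(/C=N/NC(=O)c2nn(-c3ccnc4cc(Cl)ccc34)c(-c3ccc(Cl)cc3)c2C)ccc1O` has yet to be measured. It carries 7-chloroquinolin-4-yl in place of 2,4-dichlorophenyl on an aromatic nitrogen. Going by the values given here, the one measured step at that place is a 1.4-fold lower number from compound 1 to compound 2 (0.14 log units; within the scatter), but it swaps only one dichlorophenyl for another. On these data alone, with this single guide, no step beyond the scatter is expected in this assay, and either direction stays open. The expected change is a 1.2-fold lower number from compound 1 to compound 3 (0.07 log units; within the scatter). Compound 3 is estimated at 3000000 nM, with a range of 1000000 nM to 9000000 nM.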

Compound 3, half-maximal effective concentration: 4590000 nM
Compound 3: middle estimate off by 1.5-fold (0.18 log units), on the low side, within the range that was stated.
By their numbers in this assay, from the lowest: compounds 2, 1 and 3 (each within the scatter of the next).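

In this assay, the two-ring 7-chloroquinolin-4-yl group on the aromatic nitrogen stays within the scatter of both dichlorophenyl groups, with a 1.3-fold higher number from compound 1 to compound 3 (0.11 log units; within the scatter) and a 1.8-fold higher number from compound 2 to compound 3 (0.25 log units; within the scatter). This position therefore takes a second ring and a ring nitrogen, with one chlorine fewer, and the number shows no step beyond the scatter. No measured evidence bears on this result.

Still open, on these data alone, is whether a group of a different kind on this nitrogen, such as a plain methyl, an aminoethyl chain or a carboxylic acid, would move the number beyond the scatter.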